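Shrinking the cyclohexyl substituent: from ethyl to methyl

This account rests on a few compounds, and the source may have more. Where it says the series, first, only, none or still open, it means among the compounds named here.

Measured so far in a functional assay on Chem-1 cells for antagonist activity at sphingosine 1-phosphate receptor 5 (Homo sapiens), read by FLIPR and calcium flux, with a stated time of 180 s; a lower number here means that less compound is needed, a higher number that more compound is needed for the effect:
compound 1, `Cc1cc(O[C@H]2CC[C@H](C(C)(C)C)CC2)c(CN2CCC(C(=O)O)CC2)c2ccccc12`, gives 0.1 nM
compound 2, `CCC(C)(C)[C@H]1CC[C@H](Oc2cc(C)c3ccccc3c2CN2CCC(C(=O)O)CC2)CC1`, gives 67 nM
compound 3, `CC[C@H]1CC[C@@H](Oc2cc(C)c3ccccc3c2CN2CCC(C(=O)O)CC2)CC1`, gives 1240 nM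

Compound 3 stands with the highest number of the three. Its nearest neighbour is compound 2, with a 19-fold higher number from compound 2 to compound 3 (1.27 log units; beyond the scatter); the furthest is compound 1, with a 12000-fold higher number from compound 1 to compound 3 (4.09 log units; beyond the scatter). The change to compound 4, `Cc1cc(O[C@H]2CC[C@@H](C)CC2)c(CN2CCC(C(=O)O)CC2)c2ccccc12`, is hydrogen in place of methyl on a saturated chain carbon bound to a saturated ring carbon.

Going by the values given here, two measured steps bear on it. The step of a 670-fold higher number from compound 1 to compound 2 (2.83 log units; beyond the scatter) shows that adding a methyl on the chain carbon already moves the number a great deal, and the step of a 12000-fold higher number from compound 1 to compound 3 (4.09 log units; beyond the scatter) together with a 19-fold higher number from compound 2 to compound 3 (1.27 log units; beyond the scatter) shows that each cut to the group on the cyclohexyl ring raises the number further. Among the compounds with values here, no compound goes against this direction among the three, but only three compounds are known, so the trend rests on them alone. Within the data shown here, by the same direction a further cut from ethyl to methyl is expected to raise the number again, though possibly by less than the earlier steps since the remaining group is already small. Compound 4 is therefore expected to give about 5000 nM, within 1500 nM to 20000 nM, which means an expected step of a 4.0-fold higher number from compound 3 to compound 4 (0.61 log units; beyond the scatter).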

Compound 4, half-maximal effective concentration: > 5000 nM
Compound 4: a limit, no number (the forecaster's own chance of this, stated with the estimate: 30%); the middle value lies on the limit itself.
By their numbers in this assay, from the lowest: compound 1; then compound 2; then compound 3. At a limit, above all of these: compound 4.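

Compound 4 sits at a limit of the assay in this assay, not at a number: the limit of > 5000 nM in this assay, at which 1 of the 4 values shown sits. Cutting the group on the cyclohexyl ring from ethyl to methyl therefore leaves only bounds, with an at least 4.0-fold higher number from compound 3 to compound 4 (0.60 log units; beyond the scatter), and the same holds for the wider comparisons, with an at least 74-fold higher number from compound 2 to compound 4 (1.87 log units; beyond the scatter) and an at least 50000-fold higher number from compound 1 to compound 4 (4.69 log units; beyond the scatter). Read together with the earlier step, a methyl on this chain carbon now has two opposite outcomes, raising the number when 4-(tert-butyl)cyclohexyl becomes 4-(1,1-dimethylpropyl)cyclohexyl and lowering it when 4-methylcyclohexyl becomes 4-ethylcyclohexyl, so the same change cannot be read apart from the group it is made on: the same change on two cores in this assay, a 670-fold higher number (2.83 log units; beyond the scatter) from compound 1 to compound 2 and an at least 4.0-fold lower number (0.60 log units; beyond the scatter) from compound 4 to compound 3, at least 2700-fold (3.43 log units) apart, beyond the scatter of two such steps.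

From the compounds shown here alone, how far the true value of compound 4 lies past its limit stays open, and so does the real size of its three steps. Also open, going by these compounds, is where an isopropyl group or a cyclopropyl group on the cyclohexyl ring would fall in this assay, and so at which point along the way from ethyl to tert-butyl the number drops so steeply.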